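Aryl Swap on the Shared Core: Compound 3 Awaits Measurement

The compounds below may be only part of what the source reports. "The series", "measured", "known", "first", "only" and "open" are said of these compounds alone.

Measured compounds:
- compound 1, `Cc1nc2c3ccccc3ccc2c2nc3c(ccc4ccccc43)c(-c3cccnc3)c12`, 3960 nM
- compound 2, `Cc1nc2c3ccccc3ccc2c2nc3c(ccc4ccccc43)c(-c3ccccc3Cl)c12`, 52500 nM

In a functional assay on AGS cells (Homo sapiens) for cytotoxicity, read by MTT assay, with a stated time of 48 h (a lower number here means a stronger inhibitor, a higher number a weaker inhibitor), compound 2 gives 52500 nM, the highest of the two numbers recorded; its nearest neighbour is compound 1 with 3960 nM. For the measured compounds named here, the only measured step touches the same position: a 13-fold higher number from compound 1 to compound 2 (1.12 log units; beyond the scatter). Compound 3, `Cc1ccc(-c2c3ccc4ccccc4c3nc3c2c(C)nc2c4ccccc4ccc32)cc1`, is not yet measured. It differs from compound 2 in one place: 4-methylphenyl in place of 2-chlorophenyl on an aromatic carbon. Going by the values given here, no measured step covers this particular exchange of one carbon-only ring for another, so the step from compound 1 to compound 2 bears on it only by showing that a change at this position can move this assay strongly. The expected step is a 2.6-fold lower number from compound 2 to compound 3 (0.42 log units; beyond the scatter), a modest lowering with wide uncertainty. Compound 3 is therefore estimated at 20000 nM, with a plausible range from 5000 nM to 70000 nM.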

Compound 3, half-maximal inhibitory concentration: > 80000 nM
Compound 3: a limit, no number (the forecaster's own chance of this, stated with the estimate: 10%); middle value at least 4.0-fold (0.60 log units) from the limit.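

In this assay compound 3 gives > 80000 nM, which is a limit of the assay and not a number. Exchanging 2-chlorophenyl for 4-methylphenyl gives an at least 1.5-fold higher number from compound 2 to compound 3 (0.18 log units; that floor lies within the scatter), so this swap of one carbon-only ring for another brings no lowering, though its true size cannot be read. Exchanging pyridin-3-yl for 4-methylphenyl gives an at least 20-fold higher number from compound 1 to compound 3 (1.30 log units; beyond the scatter), so a second carbon-only ring at this position, like 2-chlorophenyl, stands well apart from pyridin-3-yl, and no compound shown goes against this.

The compounds shown leave open how far compound 3 lies past its limit, and whether the ring nitrogen itself or some other difference between the rings sets the gap. They also leave open how a pyridin-4-yl ring, or a phenyl ring carrying an amine or a carboxylic acid, would read at this position.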